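A trifluoromethyl aniline on a shared core

The source may report more compounds than this note shows. Statements on the series, on what has been measured and on what is new or still open speak of the compounds shown alone.

Two compounds share a core. Compound 2 `COc1ccccc1Nc1nc(SCc2cn(CC(=O)NC(=O)Nc3ccccn3)nn2)nc(-c2ccc(C)cc2)c1C#N` gives 8580 nM in a functional assay on B16-F10 cells (Mus musculus) for inhibition, read by MTT assay, with a stated time of 72 h (a lower number here means a stronger inhibitor, a higher number a weaker inhibitor), the lowest of the two numbers. Compound 1 `COc1cc(-c2nc(SCc3cn(CC(=O)NC(=O)Nc4ccccn4)nn3)nc(Nc3cccc(C(F)(F)F)c3)c2C#N)cc(OC)c1OC` gives 24400 nM in this assay, a higher number beyond the scatter. The unmeasured compound 3 `Cc1ccc(-c2nc(SCc3cn(CC(=O)NC(=O)Nc4ccccn4)nn3)nc(Nc3cccc(C(F)(F)F)c3)c2C#N)cc1` differs from compound 2 in one place: 3-(trifluoromethyl)phenyl in place of 2-methoxyphenyl on a nitrogen on an aromatic ring. Going by the values given here, no measured pair shows this change alone, so the expectation is a modest rise in the number, toward weaker inhibition, with an expected step of a 1.6-fold higher number from compound 2 to compound 3 (0.21 log units; within the scatter). Compound 3 is estimated at 14000 nM, with a range from 5000 nM to 40000 nM.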

Compound 3, half-maximal inhibitory concentration: 9580 nM
Compound 3: the middle estimate sits 1.5-fold (0.16 log units) above what was measured; the range from low to high includes it.
By their numbers in this assay, from the lowest: compounds 2 and 3 (each within the scatter of the next); then compound 1.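

In this assay the exchange of 2-methoxyphenyl for 3-(trifluoromethyl)phenyl on a nitrogen on an aromatic ring leaves the number within the scatter (a 1.1-fold higher number from compound 2 to compound 3 (0.05 log units; within the scatter)), so these two groups cannot be told apart at this position. The clearer step lies at the other place, where 4-methylphenyl replaces 3,4,5-trimethoxyphenyl on an aromatic carbon (a 2.5-fold lower number from compound 1 to compound 3 (0.41 log units; beyond the scatter)). Nothing here explains either result.

Going by these compounds, whether an amine or a carboxylic acid on the phenyl ring at that nitrogen would also leave the number unchanged stays open. So does whether the step at the aromatic carbon would recur with 2-methoxyphenyl on the nitrogen.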